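Trading Benzoyl for Propanoyl on a Shared Core

This account rests on a few compounds, and the source may have more. Where it says the series, first, only, none or still open, it means among the compounds named here.

In a functional assay on NCI-H23 cells (Homo sapiens) for cytotoxicity, read by sulforhodamine B assay, with a stated time of 72 h (on this read-out higher numbers stand for weaker inhibition of growth and lower numbers for stronger inhibition of growth), compound 1 `O=C(Nc1ccccc1C(F)(F)F)C1CCc2ccccc2N1C(=O)c1ccccc1` gives 6340 nM. Compound 2 `O=C(Nc1ccccc1O)C1CCc2ccccc2N1C(=O)c1ccccc1` gives 3490 nM; the step of a 1.8-fold lower number from compound 1 to compound 2 (0.26 log units; within the scatter) keeps the two within the usual scatter, so compound 1 stands level with compound 2 at one end of the measured pair. Compound 3 `O=C(Nc1ccc(O)cc1)C1CCc2ccccc2N1` returns only a limit, > 100000 nM, which is the limit of > 100000 nM in this assay, at which 1 of the 3 values shown sits. Compound 4 `CCC(=O)N1c2ccccc2CCC1C(=O)Nc1ccccc1C(F)(F)F` differs from compound 1 by ethyl in place of phenyl on a carbonyl carbon. Within the data shown here, no measured step touches this carbonyl: the only measured step changed a group on an aromatic ring and stayed within the scatter, and compound 3 differs from compound 1 in more than one place. The expectation is therefore a change no larger than the scatter, a 1.3-fold higher number from compound 1 to compound 4 (0.10 log units; within the scatter). Compound 4 is estimated at 8000 nM, between 2500 nM and 30000 nM.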

Compound 4, concentration for 50% growth inhibition: > 80000 nM
Compound 4 ended at the assay's limit; the forecaster's own chance of this, stated with the estimate: 8%; middle value at least 10-fold (1.00 log units) from the limit.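

In this assay, the carbonyl position turns out to be sensitive: benzoyl to propanoyl gives an at least 12-fold higher number from compound 1 to compound 4 (1.10 log units; beyond the scatter). The value for compound 4 is a limit of the assay, not a number: the limit of > 80000 nM in this assay, at which 1 of the 4 values shown sits.

On this shared core, then, ethyl does not stand in for phenyl on the carbonyl, whereas the earlier swap of hydroxy for trifluoromethyl on the aromatic ring stayed within the scatter. Still open, going by these compounds, is whether the aromatic ring itself counts, which a cyclohexyl or a longer chain such as butyl on this carbonyl could test. Also open, on these data alone, is whether compound 2 would respond to propanoyl in the same way.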